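The source may hold more compounds than are shown below. What is called first, only, known or untested is meant among the compounds shown, and "the series" means these compounds.

Measured compounds:
Compound 1 `Nc1cc[n+](Cc2ccc(OCc3ccccc3)cc2)cc1`: 77000 nM
Compound 2 `c1ccc(COc2ccc(CNc3ccncc3)cc2)cc1`: 233000 nM

In an assay on isolated protein for inhibition of serine protease 1 (Homo sapiens) (a higher number here means a weaker inhibitor, a lower number a stronger inhibitor), compound 1 stands at the lowest of the two numbers, and the step to compound 2 is a 3.0-fold higher number from compound 1 to compound 2 (0.48 log units; beyond the scatter). Compound 3 `Nc1cc[n+](Cc2ccc(OC(c3ccccc3)c3ccccc3)cc2)cc1` differs from compound 1 by phenyl in place of hydrogen on a saturated chain carbon bound to an aromatic carbon and an oxygen on an aromatic ring. Within the data shown here, the one measured step concerns a different part of the molecule and does not bear on this change, so nothing measured points to a sizeable shift in either direction. Compound 3 is therefore expected to give about 60000 nM, with a range from 15000 nM to 250000 nM, a step of a 1.3-fold lower number from compound 1 to compound 3 (0.11 log units; within the scatter) that is estimated to stay within the scatter.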

Compound 3, inhibition constant: 517000 nM
The estimate for compound 3 lay 8.6-fold (0.94 log units) below the measured number, and the stated range ends below it.
By their numbers in this assay, from the lowest: compound 1; then compound 2; then compound 3.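

In this assay, phenyl in place of hydrogen on the saturated chain carbon bound to an aromatic carbon and an oxygen gives a 6.7-fold higher number from compound 1 to compound 3 (0.83 log units; beyond the scatter) and so marks a weaker inhibitor. Among these compounds, the earlier step concerned another part of the molecule, so this is the first sign that this carbon affects the number, and that adding phenyl here costs rather than helps. Nothing available explains this shift. Going by these compounds, whether methyl on the same carbon would also raise the number remains open, as does whether an amine there would lower it.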